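The compounds below may be only part of what the source reports. "The series", "measured", "known", "first", "only" and "open" are said of these compounds alone.

Compound 3 `CCCCCCCCc1ccc(OCC(=O)Cn2nnc(Cc3ccccc3)n2)cc1` gives < 5% in an ADME assay on S9 fraction from liver (Rattus norvegicus) for metabolic stability, read by LC-MS, using NADPH, with a stated time of 30 min (a higher number here means that more of the compound is left, a lower number that less of the compound is left), which is a limit of the assay and not a number. That places compound 3 at the limit of < 5% in this assay, at which 1 of the 3 values shown sits. On the same read-out, compound 1 `CCCCCCCCc1ccc(OCC(=O)Cn2nnc(-c3ccc(S(=O)(=O)N(C)C)cc3)n2)cc1` gives 65% and compound 2 `CCCCCCCCc1ccc(OCC(=O)Cn2nnc(-c3ccccn3)n2)cc1` gives 30%.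

Compound 4 `CCCCCCCCc1ccc(OCC(=O)Cn2nnc(-c3cccc(C(=O)O)c3)n2)cc1` has 3-carboxyphenyl in place of benzyl on an aromatic carbon. Three measured steps changed the group at this same carbon. Two of them put benzyl there, giving a number at least 60 percentage points lower from compound 1 to compound 3 (beyond the scatter) and a number at least 25 percentage points lower from compound 2 to compound 3 (beyond the scatter). The third gave a number 35 percentage points lower from compound 1 to compound 2 (beyond the scatter), so the choice of group here can matter a great deal.

Compound 4 gives up benzyl and, like compound 1, carries a substituted phenyl ring, so those benzyl steps should run in reverse. A large rise in this assay is therefore expected, although a carboxyphenyl group has not yet been measured here. The expected change is a number at least 40 percentage points higher from compound 3 to compound 4 (beyond the scatter). For compound 4 the estimated value is 45%, with an expected range from 15% to 75%.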

Compound 4, percent of the compound remaining: < 5%
Compound 4: a limit, no number; the forecaster's own chance of this, stated with the estimate: 5%; middle value at least 40 percentage points away from the limit.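

Having a phenyl ring on this carbon does not by itself keep the compound from being lost in this assay: replacing 4-(dimethylsulfamoyl)phenyl with 3-carboxyphenyl gives a number at least 60 percentage points lower from compound 1 to compound 4 (beyond the scatter). Replacing pyridin-2-yl with 3-carboxyphenyl gives a number at least 25 percentage points lower from compound 2 to compound 4 (beyond the scatter), so the outcome depends on the particular aromatic group and not simply on there being an aromatic ring at this position. The value of compound 4 is a limit of the assay and not a number, and the step to it from compound 3 cannot be read: the limit of < 5% in this assay, at which 2 of the 4 values shown sit.

From the compounds shown here alone, it remains open whether a 4-carboxyphenyl group, or a methyl ester in place of the carboxylic acid, would leave more of the compound. A 3-(dimethylsulfamoyl)phenyl group could likewise show how much depends on the substituent's position on the ring rather than on its identity.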